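The source may hold more compounds than are shown below. What is called first, only, known or untested is meant among the compounds shown, and "the series" means these compounds.

Values in an ADME assay on HEK-293T cells (Homo sapiens) for cytotoxicity, read by CCK-8 assay, with a stated time of 48 h; a lower number here means a stronger inhibitor, a higher number a weaker inhibitor:
- Compound 1 `O=S(=O)(NCCNC(=S)Nc1cccc(Cl)c1)c1ccc(-c2ccccc2OCc2cccc(O)c2)s1`: 17400 nM
- Compound 2 `O=S(=O)(NCCNC(=S)Nc1cccc(Cl)c1)c1ccc(-c2ccccc2OCc2ccccc2)s1`: 10200 nM
- Compound 3 `O=[N+]([O-])c1ccc(Oc2ccccc2-c2ccc(S(=O)(=O)NCCNC(=S)Nc3cccc(Cl)c3)s2)cc1`: 4990 nM

Compound 1 has the highest of the three numbers, with a 1.7-fold lower number from compound 1 to compound 2 (0.23 log units; within the scatter) and a 3.5-fold lower number from compound 1 to compound 3 (0.54 log units; beyond the scatter). Compound 4 `COc1ccc(NC(=O)NCCNS(=O)(=O)c2ccc(-c3ccccc3OCc3cccc(O)c3)s2)cc1` differs from compound 1 in one place: a group of 11 heavy atoms (8 carbon, 1 nitrogen, 2 oxygen; one six-membered aromatic ring of carbon only) in place of a group of 10 heavy atoms (7 carbon, 1 nitrogen, 1 sulfur, 1 chlorine; one six-membered aromatic ring of carbon only), on an amine nitrogen. Within the data shown here, no measured step changes that group. The nearest guide is the size of the steps made on the oxygen on an aromatic ring, which also include a 2.0-fold lower number from compound 2 to compound 3 (0.31 log units; beyond the scatter). On these data alone, these are at most modest, so no step beyond the scatter is expected in this assay, and the direction stays open. The expected change is a 1.1-fold higher number from compound 1 to compound 4 (0.06 log units; within the scatter). For compound 4 the estimate is 20000 nM, with an expected range of 8000 nM to 50000 nM.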

Compound 4, half-maximal inhibitory concentration: > 20000 nM
Compound 4: only a limit was reported; the forecaster's own chance of this, stated with the estimate: 15%; the middle value sits exactly at the limit.
By their numbers in this assay, from the lowest: compound 3; then compounds 2 and 1 (each within the scatter of the next). At a limit, above all of these: compound 4.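

Only one change at the amine nitrogen is shown here, the (4-methoxyphenyl)carbamoyl group entering on the hydroxybenzyl series. In this assay compound 4 gives > 20000 nM, which is a limit and not a number. The step reads an at least 1.1-fold higher number from compound 1 to compound 4 (0.06 log units; that floor lies within the scatter), so only a floor is known, and compound 4 alone sits at that limit: the limit of > 20000 nM in this assay, at which 1 of the 4 values shown sits.

On these data alone, how far compound 4 lies past the limit stays open. Also open, as far as these compounds go, is how an amine or a carboxylic acid on the aromatic ring of this group would read.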